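This account rests on a few compounds, and the source may have more. Where it says the series, first, only, none or still open, it means among the compounds named here.

Working notes on the series. Compound 1 `CCOc1ccc(/N=C/c2c(-c3ccccc3)[n+]([O-])c3ccc(OC)cc3[n+]2[O-])cc1` has been run in a functional assay on U-251 cells (Homo sapiens) for inhibition, read by sulforhodamine B assay, with a stated time of 48 h; a lower number here means a stronger inhibitor, a higher number a weaker inhibitor; in this assay compound 1 gives > 10 ug/mL, which is a limit of the assay and not a number. Compound 2 `CCOc1ccc(NCc2nc3cc(OC)ccc3[n+]([O-])c2-c2ccccc2)cc1` has been run in the same way; in this assay compound 2 gives > 10 ug/mL, again a limit rather than a number. Compound 3 `COc1ccc(NC(=O)Nc2c(C)[n+]([O-])c3ccc(Cl)cc3[n+]2[O-])cc1` belongs to the urea branch of the series; in this assay compound 3 gives > 10 ug/mL, once more a limit and not a number. For the measured compounds named here, compound 3 therefore stands exactly where every other value shown stands, at the limit of > 10 ug/mL in this assay, at which 3 of the 3 values shown sit, and no measured step between any two of the three compounds exists to give a sense of how the numbers move.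

Compound 4 `COc1ccc(NC(=O)Nc2c(C)[n+]([O-])c3ccc(OC)cc3[n+]2[O-])cc1` is the next point, reached from compound 3 by a single change: methoxy in place of chloro on an aromatic carbon. Nothing measured in the series sizes a change of this kind. Given that compound 3 sits at the limit, the expected step that the limit leaves unreadable from compound 3 to compound 4 in this assay is none beyond the scatter, with the result most likely another limit. Compound 4 is accordingly estimated at 15 ug/mL, within a range of 5 ug/mL to 50 ug/mL.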

Compound 4, half-maximal inhibitory concentration: > 10 ug/mL
Compound 4: no number, only a limit (the forecaster's own chance of this, stated with the estimate: 75%); the middle value is on the limit's open side.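

No step can be read from compound 3 to compound 4 in this assay because both results are limits and not numbers: the limit of > 10 ug/mL in this assay, at which 4 of the 4 values shown sit. The compounds shown leave open where any of them would give an actual number in this read-out, and how far methoxy in place of chloro on an aromatic carbon moves it.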